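Dropping One Fluoro Ortho to Trifluoromethyl

A few compounds are considered here, and "the series" means these few. Any claim that something is new, unique, unknown or untested is made for them only; others in the source may bear on it.

Of the compounds shown here, two built on one shared core have been tested in an in vitro ADME assay on microsomes from liver (Homo sapiens) for metabolic stability, with a stated time of 60 min, tested at 1 uM; on this read-out higher numbers stand for fast clearance and lower numbers for slow clearance. Compound 1 `COc1ccc(-c2cc(-c3ccc(S(C)(=O)=O)cc3)cnc2N)cn1` gives in this assay a limit, < 28 mL.min-1.g-1, and not a number. That reading is the limit of < 28 mL.min-1.g-1 in this assay, at which 1 of the 2 values shown sits. Going by the values given here, compound 2 `CS(=O)(=O)c1ccc(-c2cnc(N)c(-c3ccc(C(F)(F)F)c(F)c3)c2)cc1` gives in this assay 14 mL.min-1.g-1, which is the only actual number among the values shown, so there is no measured step on which to build a comparison.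

Compound 3 `CS(=O)(=O)c1ccc(-c2cnc(N)c(-c3ccc(C(F)(F)F)cc3)c2)cc1` has not yet been measured. It differs from compound 2 in one place: hydrogen in place of fluoro on an aromatic carbon. The fluoro that leaves sits ortho to the trifluoromethyl group and meta to a large group, and only a hydrogen atom takes its place.

Among the compounds with values here, with no measured step to lean on, the expected change from compound 2 to compound 3 in this assay, a 1.2-fold higher number from compound 2 to compound 3 (0.08 log units; within the scatter), is small and within the usual scatter. Compound 3 is therefore estimated to give 17 mL.min-1.g-1, with a likely range from 8 mL.min-1.g-1 to 35 mL.min-1.g-1.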

Compound 3, intrinsic clearance in microsomes: < 7 mL.min-1.g-1
Compound 3: only a limit was reported; the forecaster's own chance of this, stated with the estimate: 25%; middle value at least 2.4-fold (0.38 log units) away from the limit.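

Hydrogen in place of fluoro on this aromatic carbon, ortho to a trifluoromethyl group, gives in this assay an at least 2.0-fold lower number from compound 2 to compound 3 (0.30 log units; that floor lies within the scatter). Going by these compounds alone, this is the first step that can be read on this core, and it shows that this fluoro is not required to keep the number low on this read-out, as clearance does not climb once the fluoro is gone. Compound 3 gives a limit and not a number, so the true size of the step stays unknown: the limit of < 7 mL.min-1.g-1 in this assay, at which 1 of the 3 values shown sits.

The compounds shown leave open whether a chloro, a methyl or a nitrile on this same carbon would keep the number as low. Going by these compounds, it also stays open whether this change would read the same way with a group other than trifluoromethyl on that ring, such as an amine.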